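Swapping a Side Group on a Saturated Ring Carbon

The source may report more compounds than this note shows. Statements on the series, on what has been measured and on what is new or still open speak of the compounds shown alone.

Compound 1 `Cc1cc(O)c(C2=NN(c3ccc(S(N)(=O)=O)cc3)C(c3ccccc3O)C2)cc1Cl`: 60500 nM in a functional assay on A549 cells (Homo sapiens) for antiproliferative activity, with a stated time of 48 h; on this read-out higher numbers stand for lower toxicity in this test and lower numbers for higher toxicity in this test.
Compound 2 `Cc1cc(O)c(C2=NN(c3ccc(S(N)(=O)=O)cc3)C(/C=C/c3ccccc3)C2)cc1Cl`: 86000 nM in this assay.

Among the measured compounds shown here, compound 2 cannot be set apart from compound 1 on these numbers: the single step known, a 1.4-fold higher number from compound 1 to compound 2 (0.15 log units; within the scatter), is within the scatter. Compound 3 `COc1ccc(C2CC(c3cc(Cl)c(C)cc3O)=NN2c2ccc(S(N)(=O)=O)cc2)cc1OC` differs from compound 2 by 3,4-dimethoxyphenyl in place of 2-phenylethenyl on a saturated ring carbon. For the measured compounds named here, only that earlier step bears on this change, and it was small, so a further swap of the group on this saturated ring carbon is expected to move the number little in this assay. Compound 3 is estimated at 70000 nM, with a range from 35000 nM to 140000 nM, an expected step of a 1.2-fold lower number from compound 2 to compound 3 (0.09 log units; within the scatter).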

Compound 3, concentration lethal to 50% of the cells: > 100000 nM
Compound 3: a limit, no number; the forecaster's own chance of this, stated with the estimate: 15%; middle value at least 1.4-fold (0.15 log units) from the limit.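

In this assay compound 3 gives a limit of the assay, not a number: the limit of > 100000 nM in this assay, at which 1 of the 3 values shown sits.

On these data alone, its steps are therefore floors only, an at least 1.1-fold higher number from compound 2 to compound 3 (0.06 log units; that floor lies within the scatter) and an at least 1.6-fold higher number from compound 1 to compound 3 (0.21 log units; that floor lies within the scatter), so the true size of each remains unknown. Even so, 3,4-dimethoxyphenyl on this saturated ring carbon gives no sign of higher toxicity in this test than the two earlier groups.

Open, as far as these compounds go, is whether a methyl group or an amine at this position would lower the number. Also open, from the compounds shown here alone, is how far past the limit the true value of compound 3 lies.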